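From 6-methoxypyridin-3-yl to 4-hydroxyphenyl on a shared core

A few compounds are considered here, and "the series" means these few. Any claim that something is new, unique, unknown or untested is made for them only; others in the source may bear on it.

- compound 1 `CC1=C(c2nc(-c3ccc(C#N)cc3)cs2)C(c2ccc(Cl)nc2)NC(=O)N1` gives 91.7% in the first test below
- compound 2 `CC1=C(c2nc(-c3ccc(C#N)cc3)cs2)C(c2ccc(Br)nc2)NC(=O)N1` gives 98.3% in the same test
- compound 3 `COc1ccc(C2NC(=O)NC(C)=C2c2nc(-c3ccc(C#N)cc3)cs2)cn1` gives 100% in the same test

In an ADME assay on a cell-free system (plasma, Rattus norvegicus) for metabolic stability, read by LC-MS, with a stated time of 1 h, tested at 100 uM (a higher number here means that more of the compound is left, a lower number that less of the compound is left), compound 3 gives 100% and lies within the scatter of both compound 1 and compound 2. Compound 4 `CC1=C(c2nc(-c3ccc(C#N)cc3)cs2)C(c2ccc(O)cc2)NC(=O)N1` carries one change, 4-hydroxyphenyl in place of 6-methoxypyridin-3-yl on a saturated ring carbon that is, 4-hydroxyphenyl in place of 6-methoxypyridin-3-yl on a saturated ring carbon. The measured steps only exchange a group on an aromatic carbon, so they bear on this change indirectly. The steps of a number 6.6 percentage points higher from compound 1 to compound 2 (within the scatter) and a number 8.3 percentage points higher from compound 1 to compound 3 (within the scatter) and a number 1.7 percentage points higher from compound 2 to compound 3 (within the scatter) all stay within the scatter. None of them replaces a whole ring, which leaves real uncertainty. A step within the scatter is expected, and a number 5 percentage points lower from compound 3 to compound 4 (within the scatter) is the estimate. Compound 4 is estimated at 95% with 84% to 103% as the expected range.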

Compound 4, percent of the compound remaining: 100%
Estimate against measurement, compound 4: 5 percentage points below, within the range that was stated.
By their numbers in this assay, from the lowest: compounds 1, 2, 3 and 4 (each within the scatter of the next).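

In this assay the step of no change at the digits printed from compound 3 to compound 4 (within the scatter) and the step of a number 1.7 percentage points higher from compound 2 to compound 4 (within the scatter) and the step of a number 8.3 percentage points higher from compound 1 to compound 4 (within the scatter) show that a whole ring can be exchanged on this saturated ring carbon without leaving the scatter. Within the data shown here, a carbon-only ring carrying a hydroxy group thus serves here as well as the pyridine rings of the earlier compounds. Nothing available explains this result. Going by these compounds, whether an amine or a carboxylic acid in place of the hydroxy group would also stay within the scatter remains open. The compounds shown also leave open which change at this position would give a clearly lower number in this assay.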